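The source may hold more compounds than are shown below. What is called first, only, known or untested is meant among the compounds shown, and "the series" means these compounds.

In an in vitro ADME assay on microsomes from liver (Homo sapiens) for metabolic stability, with a stated time of 15 min (on this read-out higher numbers stand for fast clearance and lower numbers for slow clearance), compound 1 (`COCc1cc(OC)c(-c2cccc3c(N(CC4CCOCC4)CC4CC4)c(C)nn23)c(OC)c1`) gives 110 mL.min-1.g-1 as the lower of the two measured numbers, and compound 2 (`CCc1nn2c(-c3c(OC)cccc3OC)cccc2c1N(CC1CCOCC1)CC1CC1`) gives 740 mL.min-1.g-1 as the higher. Compound 3 (`COCc1cc(OC)c(-c2cccc3c(N(CC4CCOCC4)CC4CC4)c(SC)nn23)c(OC)c1`) has methylsulfanyl in place of methyl on an aromatic carbon of the core of compound 1 (methylsulfanyl in place of methyl on an aromatic carbon). Among the measured compounds shown here, no measured pair isolates this change. A small rise in clearance, close to the usual scatter, is expected, and the estimated step is a 1.8-fold higher number from compound 1 to compound 3 (0.26 log units; within the scatter) in this assay on this limited evidence. Compound 3 is estimated at 200 mL.min-1.g-1 with an expected range from 90 mL.min-1.g-1 to 450 mL.min-1.g-1 for its measurement.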

Compound 3, intrinsic clearance in microsomes: 340 mL.min-1.g-1
Compound 3: middle estimate off by 1.7-fold (0.23 log units), on the low side; the measured number falls inside the stated range.
By their numbers in this assay, from the lowest: compound 1; then compound 3; then compound 2.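

In this assay, among the compounds shown here, the new pair gives the first isolated reading at this aromatic carbon of the core: methylsulfanyl in place of methyl brings a 3.1-fold higher number from compound 1 to compound 3 (0.49 log units; beyond the scatter) on an otherwise unchanged compound. The read-out therefore responds to what sits at this position, a point the two earlier compounds, which differ in more than one place, could not show. Nothing at hand accounts for the step. Still open, as far as these compounds go, is how a methoxy group, a chlorine atom or an amine would read at this carbon. From the compounds shown here alone, whether the step carries over to other substituents on the shared core also remains open.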